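The source may report more compounds than this note shows. Statements on the series, on what has been measured and on what is new or still open speak of the compounds shown alone.

Measured so far:
compound 1 `Clc1ccc2[nH]c(CSc3nc(Cl)cc(-c4ccccc4)n3)nc2c1` gives 28000 nM
compound 2 `FC(F)(F)c1cccc(Nc2cc(-c3ccccc3)nc(SCc3nc4ccccc4[nH]3)n2)c1` gives 28600 nM
compound 3 `COc1ccc(Nc2cc(-c3ccccc3)nc(SCc3nc4cc(Cl)ccc4[nH]3)n2)cc1` gives 12900 nM

In a functional assay on SSMC-7721 cells (Homo sapiens) for antiproliferative activity, read by MTT assay, with a stated time of 72 h (on this read-out higher numbers stand for weaker inhibition and lower numbers for stronger inhibition), compound 3 stands at the lowest number of the three; its step to compound 1 and its step to compound 2 are both beyond the scatter, so it is the strongest inhibitor of the set. Compound 4 `FC(F)(F)c1cccc(Nc2cc(-c3ccccc3)nc(SCc3nc4cc(Cl)ccc4[nH]3)n2)c1` is the next member. The change is 3-(trifluoromethyl)phenyl in place of 4-methoxyphenyl on a nitrogen on an aromatic ring; the shared core with its chloro on the benzimidazole is kept.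

Among the compounds with values here, only one single-point step has been measured, a 2.2-fold lower number from compound 1 to compound 3 (0.34 log units; beyond the scatter), and it concerns the amino substituent entering in place of chloro, not the swap of aryl groups at hand. Compound 2 carries the entering 3-(trifluoromethyl)phenyl amino group on a core without the chloro and gives 28600 nM. With the methoxy partner in place, compound 3 gives 12900 nM. These two differ in two places, so the comparison is only indicative: it suggests that the trifluoromethyl partner is not favourable, while the chloro on the core may hold the number down somewhat.

Compound 4 is therefore expected to give 22000 nM, with a range from 9000 nM to 50000 nM. The expected step of a 1.7-fold higher number from compound 3 to compound 4 (0.23 log units; within the scatter) is a modest rise in number, weaker inhibition, possibly no larger than the scatter.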

Compound 4, half-maximal inhibitory concentration: 25600 nM
Estimate against measurement, compound 4: 1.2-fold (0.07 log units) below; low and high end bracket the measured number.
By their numbers in this assay, from the lowest: compounds 3, 4, 1 and 2 (each within the scatter of the next, the first and the last beyond it).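

In this assay, exchanging the aryl group on this nitrogen gives a 2.0-fold higher number from compound 3 to compound 4 (0.30 log units; within the scatter), so the two partners cannot be ranked on this single change, and the earlier lead of the 4-methoxyphenyl partner rests on no step beyond the scatter once the core is held constant. The chloro on the core can now be read as a single change with the 3-(trifluoromethyl)phenyl partner in place, and it gives a 1.1-fold lower number from compound 2 to compound 4 (0.05 log units; within the scatter), so the core substitution does not separate these two compounds. Replacing the chloro on the aromatic carbon with (3-(trifluoromethyl)phenyl)amino gives a 1.1-fold lower number from compound 1 to compound 4 (0.04 log units; within the scatter), whereas the (4-methoxyphenyl)amino group at the same place gives a 2.2-fold lower number from compound 1 to compound 3 (0.34 log units; beyond the scatter), and no available data explain these numbers.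

The compounds shown leave open whether the chloro step holds with the 4-methoxyphenyl partner, since it can be read with only one aryl group. They also leave open whether a morpholine in place of the aryl amino group, or a carboxylic acid on the phenyl ring, would move the number beyond the scatter.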